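The source may hold more compounds than are shown below. What is called first, only, known or untested is meant among the compounds shown, and "the series" means these compounds.

Measured so far:

Compound 1, `Fc1cnc(Nc2cc3[nH]c(-c4cccc(C(F)(F)F)c4)nc3cn2)c(F)c1` — in a physicochemical assay for solubility, using the shake flask method, in simulated intestinal fluid, measured as kinetic solubility, with a stated time of 20 h, at pH 6.5 (a higher number here means a more soluble compound, a lower number a less soluble compound), compound 1 gives >= 50000 nM, which is a limit of the assay and not a number.
Compound 2, `FC(F)(F)c1ccc(Nc2cc3[nH]c(-c4cccc(C(F)(F)F)c4)nc3cn2)nc1` — in this assay compound 2 gives >= 50000 nM, again a limit of the assay and not a number.

Within the data shown here, compound 2 therefore stands at the upper end of what the assay can report; the only measured step, a step that the two limits leave unreadable from compound 1 to compound 2, cannot be sized, since both values sit at the limit of >= 50000 nM in this assay, at which 2 of the 2 values shown sit. Compound 3, `NC(=O)c1ccc(Nc2cc3[nH]c(-c4cccc(C(F)(F)F)c4)nc3cn2)nc1`, differs from compound 2 by carbamoyl in place of trifluoromethyl on an aromatic carbon, in words: carbamoyl in place of trifluoromethyl on an aromatic carbon. Among the measured compounds shown here, no measured step bears on this change itself. With compound 2 already at the limit, the expectation for compound 3 in this assay is no change beyond the scatter, a step that the limit leaves unreadable from compound 2 to compound 3, with the reported value again most likely a limit. Estimated value for compound 3: 60000 nM, range 20000 nM to 150000 nM.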

Compound 3, solubility: < 5000 nM
Compound 3 gave a limit, no number; the forecaster's own chance of this, stated with the estimate: 75%; at least 12-fold (1.07 log units) between middle value and limit.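

In this assay, among these compounds, carbamoyl in place of trifluoromethyl, two atoms from the ring nitrogen, gives the first readable change at this position: an at least 10-fold lower number from compound 2 to compound 3 (1.00 log units; beyond the scatter). Compound 3 gives < 5000 nM, which is a limit of the assay and not a number. The 5-carbamoylpyridin-2-yl group in place of 3,5-difluoropyridin-2-yl gives an at least 10-fold lower number from compound 1 to compound 3 (1.00 log units; beyond the scatter), so these two steps have a direction, whereas the step from compound 1 to compound 2 cannot be read.

On these data alone, the full size of both steps stays open because compound 3 sits at a limit: the limit of < 5000 nM in this assay, at which 1 of the 3 values shown sits. Also open is whether this lower number is particular to carbamoyl, or whether a nitrile, a carboxylic acid or an amine at the same position would give a similar one.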